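The compounds below may be only part of what the source reports. "The series", "measured", "known", "first", "only" and "open" are said of these compounds alone.

Measured compounds:
- compound 1 `CN(C)c1ccc2c(=O)c(C(=O)Nc3cc(F)cc(F)c3)cn(-c3ccc(Cl)c(OCCCCCCC[N+]45CCN(CC4)CC5)c3)c2n1`: in an assay on LX2 cells for inhibition of COL1A1 promoter (Homo sapiens), read by a luciferase reporter, with a stated time of 24 h, tested at 20 uM (on this read-out lower numbers stand for a weaker effect and higher numbers for a stronger effect at the one concentration tested), compound 1 gives 8.08%
- compound 2 `CN(C)c1ccc2c(=O)c(C(=O)Nc3cc(F)cc(F)c3)cn(-c3ccc(Cl)c(OCCCCCCC[N+]4(C)CCCC4)c3)c2n1`: compound 2 gives 51%
- compound 3 `Cc1ccc(-n2cc(C(=O)Nc3cc(F)cc(F)c3)c(=O)c3ccc(N(C)C)nc32)cc1OCCCCCCC[N+]1(C)CCN(C)CC1`: compound 3 gives 10.4%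

Among the measured compounds shown here, compound 3 stands second highest of the three numbers, though its gap to compound 1 lies within the scatter; only compound 2 stands clearly apart, and the one measured step, a number 42.9 percentage points higher from compound 1 to compound 2 (beyond the scatter), concerns the charged amine at the end of the chain, not the aromatic ring.

Compound 4 `CN1CC[N+](C)(CCCCCCCOc2cc(-n3cc(C(=O)Nc4cc(F)cc(F)c4)c(=O)c4ccc(N(C)C)nc43)ccc2Cl)CC1` is made from compound 3 by chloro in place of methyl on an aromatic carbon. No measured step changes this position: compounds 1 and 2 already carry chloro there, compound 3 carries methyl, and each of them also differs in the amine, so the effect of this exchange alone is not shown by the numbers. Compound 1, which shares the chloro with compound 4, and compound 3 lie within the scatter of each other in this assay.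

Compound 4 is therefore expected to give 14%, with a range from 0% to 35%. The expected step of a number 3.6 percentage points higher from compound 3 to compound 4 (within the scatter) is estimated to stay within the scatter, in no firm direction.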

Compound 4, a percentage reported as inhibition, at one concentration (the size of the read-out at that concentration, not a potency): 27.5%
The estimate for compound 4 lay 13.5 percentage points below the measured number; the measured number falls inside the stated range.
By their numbers in this assay, from the lowest: compounds 1 and 3 (each within the scatter of the next); then compound 4; then compound 2.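

The exchange of chloro in place of methyl on this aromatic carbon can now be read alone, with the amine at the chain end held the same: in this assay it gives a number 17.1 percentage points higher from compound 3 to compound 4 (beyond the scatter). With chloro kept in place, the amine at the chain end still sets the read-out in both directions, with a number 23.5 percentage points lower from compound 2 to compound 4 (beyond the scatter) and a number 19.4 percentage points higher from compound 1 to compound 4 (beyond the scatter), so the one-ring six-membered group of compound 4 lies between the other two amine groups. Nothing available explains either change.

The compounds shown leave open whether the same exchange would give a similar step with the five-membered ring group of compound 2 at the chain end. They also leave open how a fluoro, bromo or methoxy group on this aromatic carbon would compare with chloro.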